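This account rests on a few compounds, and the source may have more. Where it says the series, first, only, none or still open, it means among the compounds named here.

Measured compounds:
- compound 1, `CC[C@@H]1C(=O)N(C)c2cnc(Nc3ccc(S(N)(=O)=O)cc3)nc2N1C1CCCC1`: 5290 nM
- compound 2, `CCC1C(=O)N(C)c2cnc(-n3ccc4cc(C(=O)NCC(C)C)ccc43)nc2N1c1ccn(C)n1`: 10200 nM
- compound 3, `CC[C@@H]1C(=O)N(C)c2cnc(-n3ccc4cc(C(=O)NCC(C)C)ccc43)nc2N1C1CCCC1`: "not active" (no number reported)

In a functional assay on NCI-H1975 cells (Homo sapiens) for antiproliferative activity, read by CCK-8 assay, with a stated time of 72 h (a higher number here means a weaker inhibitor of growth, a lower number a stronger inhibitor of growth), compound 1 gives 5290 nM and compound 2 gives 10200 nM; compound 2 holds the higher of the two numbers, but the gap to compound 1 lies within the scatter, so no order between them can be claimed. In this assay compound 3 gives "not active" (no number reported), without a number. Compound 4, `CCNC(=O)c1ccc2c(ccn2-c2ncc3c(n2)N(c2ccn(C)n2)C(CC)C(=O)N3C)c1`, is not yet measured. It differs from compound 2 by methyl in place of isopropyl on a saturated chain carbon bound to an amide-type nitrogen. Without a measured step of this kind, the step in this assay is expected to be small, not beyond the scatter, in either direction. Compound 4 is estimated at 12000 nM, between 5000 nM and 30000 nM, a step of a 1.2-fold higher number from compound 2 to compound 4 (0.07 log units; within the scatter) expected.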

Compound 4, concentration for 50% growth inhibition: "not active" (no number reported)
No number was reported for compound 4; the estimate stays without a comparison.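

In this assay, among these compounds, compound 4 gives "not active" (no number reported), so no step from compound 2, which gives 10200 nM, can be read. The compounds shown leave open how far isobutylcarbamoyl to ethylcarbamoyl shifts growth inhibition. No evidence on a cause is available.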